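Swapping methyl for fluoro on an aromatic carbon

The compounds below may be only part of what the source reports. "The series", "measured", "known", "first", "only" and "open" are said of these compounds alone.

Measured compounds:
compound 1 `Cc1cc(-c2ccccc2C(F)(F)F)cc(C)c1Nc1ccnc(Nc2ccc(C#N)cc2)n1` with 4210 nM
compound 2 `Cc1cc(C)cc(-c2cc(C)c(Nc3ccnc(Nc4ccc(C#N)cc4)n3)c(C)c2)c1` with 4140 nM
compound 3 `Cc1ccccc1-c1cc(C)c(Nc2ccnc(Nc3ccc(C#N)cc3)n2)c(C)c1` with 3820 nM

In an ADME assay on MT4 cells (Homo sapiens) for cytotoxicity, read by MTT assay, with a stated time of 4 days (on this read-out higher numbers stand for lower toxicity in this test and lower numbers for higher toxicity in this test), compound 3 gives 3820 nM, and this number sits together with compounds 1 and 2 inside the usual scatter, so nothing separates the three. Compound 4 `Cc1cc(-c2ccccc2F)cc(C)c1Nc1ccnc(Nc2ccc(C#N)cc2)n1` is not yet measured; it differs from compound 3 by fluoro in place of methyl on an aromatic carbon. For the measured compounds named here, no measured step replaces methyl by fluoro, but the steps of a 1.1-fold lower number from compound 1 to compound 3 (0.04 log units; within the scatter) and a 1.1-fold lower number from compound 2 to compound 3 (0.03 log units; within the scatter) both change the same part of the shared core and both stay within the scatter. From this the step of a 1.0-fold higher number from compound 3 to compound 4 (0.02 log units; within the scatter) is expected to be small, with no direction beyond the scatter. Compound 4 is therefore estimated at 4000 nM, with a range from 2000 nM to 8000 nM.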

Compound 4, half-maximal cytotoxic concentration: 2120 nM
Compound 4: middle estimate off by 1.9-fold (0.28 log units), on the high side; measured number inside the range.
By their numbers in this assay, from the lowest: compounds 4, 3, 2 and 1 (each within the scatter of the next).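

In this assay, the new fluoro compound brings three steps: a 1.8-fold lower number from compound 3 to compound 4 (0.26 log units; within the scatter) and a 2.0-fold lower number from compound 2 to compound 4 (0.29 log units; within the scatter) and a 2.0-fold lower number from compound 1 to compound 4 (0.30 log units; within the scatter). Even with fluoro at this place, ortho to a large group, the four compounds therefore remain inside the usual scatter, so fluoro, methyl and trifluoromethyl are not told apart here. Nothing available explains these numbers. From the compounds shown here alone, whether a chloro group, a methoxy group or an amine at this place would give a step beyond the scatter stays open.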